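A few compounds are considered here, and "the series" means these few. Any claim that something is new, unique, unknown or untested is made for them only; others in the source may bear on it.

Three compounds of the series have been run in a functional assay on the whole organism (strain Wistar Albino) for inhibition, with Rattus norvegicus as the target, read by paw edema, with a stated time of 2 h, at a dose of 20 mg/kg; a lower number here means less inhibition, a higher number more inhibition at the dose given (going by the name of the read-out). Compound 1 `Cc1cc(-c2nn3c(-c4ccoc4C)nnc3s2)c2ccccc2n1` gives 13.4%. Compound 2 `COc1ccc(Cl)c(-c2nnc3sc(Cc4c(C)[nH]c5ccc(OC)cc45)nn23)c1` gives 20%. Compound 3 `COc1ccc(Cl)c(-c2nnc3n2NC(c2ccco2)S3)c1` gives 18.7%, the second highest of the three numbers; it lies nearest to compound 2 and furthest from compound 1, yet both gaps sit within the scatter, so no order among the three can be read. Compound 4 `COc1ccc(Cl)c(-c2nnc3n2NC(c2ccc[nH]2)S3)c1` has not been measured. It differs from compound 3 in one place: 1H-pyrrol-2-yl in place of furan-2-yl on a saturated ring carbon. Going by the values given here, no pair of measured compounds shows this exchange, so its effect is unknown here. The step of a number 0.7 percentage points lower from compound 3 to compound 4 (within the scatter) is expected to stay within the scatter, in no settled direction. Compound 4 is therefore estimated at 18%, with a range from 8% to 30%.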

Compound 4, a percentage reported as inhibition, in the whole organism at one dose (the size of the read-out at that dose, not a potency): 15.2%
Compound 4: the middle estimate sits 2.8 percentage points above what was measured; the measured number falls inside the stated range.
By their numbers in this assay, from the lowest: compounds 1, 4, 3 and 2 (each within the scatter of the next).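

Going by these compounds alone, on the saturated ring carbon, the exchange of furan-2-yl for 1H-pyrrol-2-yl gives the first single-place comparison in this assay: a number 3.5 percentage points lower from compound 3 to compound 4 (within the scatter). At this dose, replacing the ring oxygen with a ring nitrogen bearing a hydrogen-bond donor therefore does not separate the pair. No available measurement bears on the reason for this result.

On these data alone, it remains open whether a phenyl ring, an amine or a longer alkyl chain on this carbon would give a step beyond the scatter. As far as these compounds go, the same exchange at other doses or times also remains open.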